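A few compounds are considered here, and "the series" means these few. Any claim that something is new, unique, unknown or untested is made for them only; others in the source may bear on it.

Compound 1 `CCc1ccc2c(c1)N(C1=CCCC1=O)CC(C)(C)S2`: 69%
Compound 2 `CC1(C)CN(C2=CCCC2=O)c2cc(N)ccc2S1`: "not determined" (no result reported)
Compound 3 `CC(=O)Nc1ccc2c(c1)N(C1=CCCC1=O)CC(C)(C)S2`: "not determined" (no result reported)

Going by the values given here, in a functional assay on aorta (Rattus norvegicus, strain Wistar), in the presence of a further agent that is not named here (a higher number here means a larger maximal response, a lower number a smaller maximal response), compound 1 gives 69% and is the only compound of the set with a number, as compound 2 and compound 3 carry no result. Compound 1 therefore stands alone, with nothing to compare it against. Compound 4 `CC1(C)CN(C2=CCCC2=O)c2ccccc2S1` differs from compound 1 in one place: hydrogen in place of ethyl on an aromatic carbon. Among the compounds with values here, no measured pair in the set shows a step of this kind, so its size cannot be read from the data; exchanging the ethyl for hydrogen is expected to move the maximal response in this assay little, if at all, beyond the scatter. The expected step is a number 4 percentage points lower from compound 1 to compound 4 (within the scatter). For compound 4 the maximal response in this assay is estimated at 65%, between 45% and 85%.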

Compound 4, largest response reached (Emax), in percent of the reference or control that the assay uses: 61%
For compound 4 the middle estimate is 4 percentage points above the measured one, and the stated range covers the measured number.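

In this assay, replacing ethyl with hydrogen on this aromatic carbon gives a number 8 percentage points lower from compound 1 to compound 4 (within the scatter), so the two compounds cannot be told apart. This first comparison at the position shows that the maximal response does not require the ethyl: the unsubstituted compound 4 keeps a response in the same range as compound 1. Nothing at hand gives a reason for this result. On these data alone, whether a longer chain or a carboxylic acid on this carbon would shift the maximal response remains open, and a single pair cannot show how far the tolerance extends.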